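From fluoro to methoxy on an aromatic ring

The source may hold more compounds than are shown below. What is called first, only, known or untested is meant among the compounds shown, and "the series" means these compounds.

Measured in a functional assay on MCF7 cells (Homo sapiens) for inhibition, read by sulforhodamine B assay; a lower number here means a stronger inhibitor, a higher number a weaker inhibitor:
- compound 1 `O=C1C(NC2CCCC2)=CC(=O)c2c1nc1n2[C@H]2OC[C@@H](O)[C@H]2OC1`: > 16000 nM
- compound 2 `O=C1C=C(Nc2ccccc2F)C(=O)c2c1nc1n2[C@H]2OC[C@@H](O)[C@H]2OC1`: 3640 nM
- compound 3 `Cc1ccc(NC2=CC(=O)c3c(nc4n3[C@H]3OC[C@@H](O)[C@H]3OC4)C2=O)cc1`: > 4000 nM

Compound 1 is reported only as a limit, > 16000 nM. Compound 3 is likewise reported only as a limit, > 4000 nM. Compound 2 alone has an actual number, 3640 nM. Compound 4 `COc1ccccc1NC1=CC(=O)c2nc3n(c2C1=O)[C@H]1OC[C@@H](O)[C@H]1OC3` is compound 2 with methoxy in place of fluoro on an aromatic carbon, ortho to a large group: methoxy in place of fluoro on an aromatic carbon. Within the data shown here, the only measured step, a step that the two limits leave unreadable from compound 1 to compound 3, changes a different group and cannot be sized, so it offers no guide. Going by these compounds, no shift beyond the usual scatter is therefore expected in this assay, and the direction stays open. The expected step is a 1.1-fold higher number from compound 2 to compound 4 (0.04 log units; within the scatter). For compound 4 the estimated value is 4000 nM, with an expected range of 1500 nM to 12000 nM.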

Compound 4, half-maximal inhibitory concentration: > 4000 nM
Compound 4 was reported as a limit; the forecaster's own chance of this, stated with the estimate: 30%; the middle value sits exactly at the limit.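

In this assay compound 4 is reported only as a limit, > 4000 nM. Methoxy in place of fluoro on an aromatic carbon, ortho to a large group, gives an at least 1.0-fold higher number from compound 2 to compound 4 (0.04 log units; that floor lies within the scatter), so this change shows no sign of a stronger inhibitor, while its true size remains unknown. This limit is also shared with another compound: the limit of > 4000 nM in this assay, at which 2 of the 4 values shown sit.

How far compound 4 truly lies from compound 2 remains unresolved. Also open, going by these compounds, is what a chloro group, a hydroxy group or an amine would do on that same aromatic carbon.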